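Cyanoguanidine series: amine-bearing side chain variant

This account rests on a few compounds, and the source may have more. Where it says the series, first, only, none or still open, it means among the compounds named here.

Compound 1 `CCC/N=C(\NC#N)Nc1cccnc1`, compound 2 `CC(C)C/N=C(\NC#N)Nc1cccnc1` and compound 3 `C=C(C)C/N=C(\NC#N)Nc1cccnc1` share one core and differ only in the chain on the saturated chain carbon bound to a double-bonded nitrogen. In a functional assay on the whole organism (blood, strain Wistar-Okamoto) with Rattus norvegicus as the target, with a stated time of 5 days (on this read-out lower numbers stand for an effect already at smaller amounts and higher numbers for an effect only at larger amounts of compound), compound 1 gives 20 mg/kg, compound 2 gives 20 mg/kg and compound 3 gives 20 mg/kg; compound 3 thus stands level with both. The steps of no change at the digits printed from compound 1 to compound 3 (within the scatter) and no change at the digits printed from compound 2 to compound 3 (within the scatter), both at this position, and also no change at the digits printed from compound 1 to compound 2 (within the scatter) show no movement. Compound 4 `CCN(CC)CC/N=C(\NC#N)Nc1cccnc1` carries the change ((diethylamino)methyl in place of 1-methylethenyl on a saturated chain carbon bound to a double-bonded nitrogen). The entering group is larger than any tried so far and brings one hydrogen-bond acceptor, so the expectation rests on the flat steps no change at the digits printed from compound 1 to compound 3 (within the scatter) and no change at the digits printed from compound 2 to compound 3 (within the scatter); a step of no change at the digits printed from compound 3 to compound 4 (within the scatter) within the scatter is expected, with a wider range than usual. For compound 4 the expected value is 20 mg/kg, with range 7 mg/kg to 60 mg/kg.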

Compound 4, minimum effective dose: > 8 mg/kg
Compound 4: a limit, no number; the forecaster's own chance of this, stated with the estimate: 10%; the middle value lies beyond the limit too.
By their numbers in this assay, from the lowest: compounds 1, 2 and 3 (each within the scatter of the next).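

In this assay compound 4 gives > 8 mg/kg, a limit and not a number, so its steps from compound 1, compound 2 and compound 3 cannot be read. Going by these compounds, whether (diethylamino)methyl in place of 1-methylethenyl changes the minimum effective dose remains open.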